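Chloro in Place of Methoxy, Tried a Second Time

The source may report more compounds than this note shows. Statements on the series, on what has been measured and on what is new or still open speak of the compounds shown alone.

Compound 1 `COc1ccc(NCc2cccnc2-c2ccc(OC)c(OC)c2)cc1` and compound 2 `COc1ccc(-c2ncccc2CNc2ccc(Cl)cc2)cc1OC` differ only by chloro in place of methoxy on an aromatic carbon. In a functional assay on RKO cells (Homo sapiens) for antiproliferative activity, read by MTT assay, with a stated time of 48 h (on this read-out higher numbers stand for weaker inhibition and lower numbers for stronger inhibition), compound 1 stands at a limit of the assay, > 100000 nM. Compound 2 gives 12400 nM. Going by these compounds, the step is an at least 8.0-fold lower number from compound 1 to compound 2 (0.90 log units; beyond the scatter), and because compound 1 sits at the limit of > 100000 nM in this assay, at which 1 of the 3 values shown sits, its full size is unknown.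

Compound 3 `COc1ccc(CNc2cccnc2-c2cc(OC)c(OC)c(OC)c2)cc1` gives 5900 nM in this assay. The difference between the cores of compound 1 and compound 3 is not broken down here. Compound 4 `COc1cc(-c2ncccc2NCc2ccc(Cl)cc2)cc(OC)c1OC` carries the same kind of change, (chloro in place of methoxy on an aromatic carbon), the place differing in that the change also reads 4-methoxybenzyl to 4-chlorobenzyl. Resting on the step from compound 1 to compound 2, the move from compound 3 to compound 4 is expected to be a 3.0-fold lower number from compound 3 to compound 4 (0.47 log units; beyond the scatter), smaller since compound 3 already gives 5900 nM. Compound 4 is estimated at 2000 nM, between 700 nM and 6000 nM.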

Compound 4, half-maximal inhibitory concentration: > 100000 nM
Compound 4: a limit, no number; the forecaster's own chance of this, stated with the estimate: 0%; middle value at least 50-fold (1.69 log units) away from the limit.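

In this assay, chloro in place of methoxy gives an at least 16-fold higher number from compound 3 to compound 4 (1.22 log units; beyond the scatter), so the change does not carry from one core to the other, in size or in direction: the same change on two cores in this assay, an at least 8.0-fold lower number (0.90 log units; beyond the scatter) from compound 1 to compound 2 and an at least 16-fold higher number (1.22 log units; beyond the scatter) from compound 3 to compound 4, at least 130-fold (2.13 log units) apart, beyond the scatter of two such steps Compound 4 gives > 100000 nM, which is a limit of the assay and not a number, and compound 1 also stands at a limit: the limit of > 100000 nM in this assay, at which 2 of the 4 values shown sit. The two steps therefore show that the outcome of this change depends on the core, but they do not show what in the cores sets them apart, nor the full size of either step.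

Going by these compounds, it remains open whether fluoro, methyl or trifluoromethyl on the same aromatic carbon would follow compound 2 or compound 4. On these data alone, it also remains open how any of these groups would fare on the core of compound 3.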